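Chain extension in a methoxy series

This account rests on a few compounds, and the source may have more. Where it says the series, first, only, none or still open, it means among the compounds named here.

Values in a functional assay on HCT-116 cells (Homo sapiens) for antiproliferative activity, read by MTT assay, with a stated time of 48 h; on this read-out lower numbers stand for stronger inhibition and higher numbers for weaker inhibition:
- compound 1 `CCCCCC(CCO)n1cnc2c(OC)ncnc21`: > 50000 nM (a limit)
- compound 2 `CCCCCCCC(CCO)n1cnc2c(OC)ncnc21`: 15300 nM
- compound 3 `CCCCCCCC(CCO)n1cnc2c(N(C)C)ncnc21`: > 50000 nM (a limit)

Compound 2 alone carries an actual number, 15300 nM. The rest of the data consist of the limit of > 50000 nM in this assay, at which 2 of the 3 values shown sit. Compound 4 `CCCCCCCCCC(CCO)n1cnc2c(OC)ncnc21` differs from compound 2 by ethyl in place of hydrogen on a saturated chain carbon, eight bonds along the chain from an aromatic nitrogen.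

For the measured compounds named here, the closest precedent is the same exchange six bonds along the chain, an at least 3.2-fold lower number from compound 1 to compound 2 (0.51 log units; beyond the scatter). Going by these compounds, that step starts from a limit, so its true size remains open. The other measured step, an at least 3.2-fold higher number from compound 2 to compound 3 (0.51 log units; beyond the scatter), concerns an aromatic carbon and not the chain, so it offers little guidance here. A further modest fall in this assay is therefore expected, though one precedent is thin support. The estimated change is a 2.8-fold lower number from compound 2 to compound 4 (0.44 log units; beyond the scatter). Compound 4 is expected at 5500 nM, with an estimated range of 1800 nM to 16000 nM.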

Compound 4, half-maximal inhibitory concentration: 2530 nM
Compound 4: the middle estimate sits 2.2-fold (0.34 log units) above what was measured, within the range that was stated.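

In this assay, for the compounds shown here, the chain extension now has a measured number at both ends for the first time, and ethyl in place of hydrogen, eight bonds along the chain from an aromatic nitrogen, gives a 6.0-fold lower number from compound 2 to compound 4 (0.78 log units; beyond the scatter). The earlier chain step started from a limit, whereas this one shows that the lowering continues further out along the chain and has a definite size. Over the whole extension, butyl in place of hydrogen gives an at least 19-fold lower number from compound 1 to compound 4 (1.29 log units; beyond the scatter), but the true size of this step stays open, since it too starts from a limit: the limit of > 50000 nM in this assay, at which 2 of the 4 values shown sit.

The compounds shown leave open whether a chain longer than that of compound 4 would lower the number further or reverse the trend. They also do not show how dimethylamino in place of methoxy, or a carboxylic acid in place of the hydroxyl, would read on this longer chain.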